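A few compounds are considered here, and "the series" means these few. Any claim that something is new, unique, unknown or untested is made for them only; others in the source may bear on it.

Compound 1 `COc1ccc(C(=O)/C=C/c2cc(Br)cc(Br)c2Oc2c([N+](=O)[O-])cc(C(F)(F)F)cc2[N+](=O)[O-])cc1` and compound 2 `COc1ccc(C(=O)/C=C/c2cc(Cl)cc(Cl)c2Oc2c([N+](=O)[O-])cc(C(F)(F)F)cc2[N+](=O)[O-])cc1` share a core whose difference is not broken down here. In a functional assay on A549 cells (Homo sapiens) for antiproliferative activity, read by MTT assay, with a stated time of 48 h (a lower number here means a stronger inhibitor, a higher number a weaker inhibitor), compound 1 gives 13.2 ug/mL, and compound 2 gives 12.6 ug/mL, the two numbers lying within the usual scatter of each other. Compound 3 `O=C(/C=C/c1cc(Br)cc(Br)c1Oc1c([N+](=O)[O-])cc(C(F)(F)F)cc1[N+](=O)[O-])c1ccc(F)cc1` carries one change from compound 1, (fluoro in place of methoxy on an aromatic carbon), and in this assay compound 3 gives 120 ug/mL, a step of a 9.1-fold higher number from compound 1 to compound 3 (0.96 log units; beyond the scatter). Compound 4 `O=C(/C=C/c1cc(Cl)cc(Cl)c1Oc1c([N+](=O)[O-])cc(C(F)(F)F)cc1[N+](=O)[O-])c1ccc(F)cc1` stands to compound 2 exactly as compound 3 stands to compound 1: the change is fluoro in place of methoxy on an aromatic carbon, made at the same place. Because the earlier step was a 9.1-fold higher number from compound 1 to compound 3 (0.96 log units; beyond the scatter), the same step is expected here, an 8.7-fold higher number from compound 2 to compound 4 (0.94 log units; beyond the scatter). On that basis compound 4 is estimated to give about 110 ug/mL in this assay, expected to fall between 40 ug/mL and 300 ug/mL.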

Compound 4, half-maximal inhibitory concentration: 29.4 ug/mL
Beside the measured number, compound 4's estimate is 3.7-fold (0.57 log units) above it; the whole stated range lies above it.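

In this assay, fluoro in place of methoxy again raises the number (a 2.3-fold higher number from compound 2 to compound 4 (0.37 log units; beyond the scatter)), so the direction of the step is the same on both cores, but its size does not carry over from one core to the other: the same change on two cores in this assay, a 9.1-fold higher number (0.96 log units; beyond the scatter) from compound 1 to compound 3 and a 2.3-fold higher number (0.37 log units; beyond the scatter) from compound 2 to compound 4, 3.9-fold (0.59 log units) apart, beyond the scatter of two such steps. This shows that the step measured on the core of compound 1 cannot be applied at full size to the core of compound 2. It does not show why the two steps differ, and one pair of cores gives no general rule for the series.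

The compounds shown leave open how an amine, a hydroxyl or a longer alkoxy chain in the place of the methoxy would fare on either core. They also leave open whether such replacements would differ between the two cores as this change does.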